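Swapping the aryl group on the hydrazone carbon

The compounds below may be only part of what the source reports. "The series", "measured", "known", "first", "only" and "open" are said of these compounds alone.

Of the compounds shown here, two on one shared core have so far been measured. In a functional assay on A549 cells (Homo sapiens) for cytotoxicity, read by MTT assay, with a stated time of 72 h (on this read-out lower numbers stand for stronger inhibition and higher numbers for weaker inhibition), compound 1 `CN(C)CCn1cnnc1-c1cc(Oc2ccc(NC(=O)N/N=C/c3c(Cl)cccc3Cl)cc2F)ccn1` gives 1410 nM, and compound 2 `CN(C)CCn1cnnc1-c1cc(Oc2ccc(NC(=O)N/N=C/c3ccccc3O[N+](=O)[O-])cc2F)ccn1` gives 1200 nM. Among the compounds with values here, the only step available is a 1.2-fold lower number from compound 1 to compound 2 (0.07 log units; within the scatter); it exchanged the aryl group on a carbon with a double bond to nitrogen and left the two numbers within the scatter of each other, so compound 2 cannot be set apart from compound 1 on what is known. Compound 3 `CN(C)CCn1cnnc1-c1cc(Oc2ccc(NC(=O)N/N=C/c3ccc(F)cc3F)cc2F)ccn1` has not yet been measured. It differs from compound 2 by 2,4-difluorophenyl in place of 2-(nitrooxy)phenyl on a carbon with a double bond to nitrogen. Within the data shown here, because the one step at this same position was within the scatter, namely a 1.2-fold lower number from compound 1 to compound 2 (0.07 log units; within the scatter), a further aryl exchange there is expected to give no step beyond the scatter in this assay. Compound 3 is therefore estimated at 1300 nM, with a range from 500 nM to 3500 nM, a step of a 1.1-fold higher number from compound 2 to compound 3 (0.03 log units; within the scatter).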

Compound 3, half-maximal inhibitory concentration: 1870 nM
For compound 3 the middle estimate is 1.4-fold (0.16 log units) below the measured one; low and high end bracket the measured number.
By their numbers in this assay, from the lowest: compounds 2, 1 and 3 (each within the scatter of the next).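

In this assay the step to 2,4-difluorophenyl is a 1.6-fold higher number from compound 2 to compound 3 (0.19 log units; within the scatter) and, against the chlorinated group, a 1.3-fold higher number from compound 1 to compound 3 (0.12 log units; within the scatter) on the same carbon with a double bond to nitrogen. The exchange removes the 2-(nitrooxy)phenyl group with its 3 hydrogen-bond acceptors and brings in a group with 0, yet the number stays within the scatter, so a second pair of aryl groups now fails to separate and 2,6-dichlorophenyl, 2-(nitrooxy)phenyl and 2,4-difluorophenyl cannot be told apart here. Nothing available explains this insensitivity. On these data alone, all three groups are substituted phenyl rings, so it remains open whether a ring bearing a carboxylic acid or an amine, or a saturated cyclohexyl group, would give a step beyond the scatter at this place.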